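Working notes: fluoro in place of methyl in compound 2

The source may hold more compounds than are shown below. What is called first, only, known or untested is meant among the compounds shown, and "the series" means these compounds.

Values in a functional assay on B16-F10 cells (Mus musculus) for antiproliferative activity, read by MTT assay, with a stated time of 48 h; a higher number here means a weaker inhibitor, a lower number a stronger inhibitor:
compound 1 `COc1ccc(-c2nn(-c3ccccc3)cc2CNc2ccc(Br)cc2)cc1`: 8060 nM
compound 2 `COc1ccc(-c2nn(-c3ccccc3)cc2CNc2ccc(C)cc2)cc1`: 8380 nM
compound 3 `COc1ccc(-c2nn(-c3ccccc3)cc2CNc2ccc(F)cc2)cc1`: not yet measured

Among the measured compounds shown here, only two numbers are available so far, and compound 2 at 8380 nM cannot be separated from compound 1. The two sit level, and neither can be ranked above the other.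

The change under review is fluoro in place of methyl on an aromatic carbon, para to a large group: fluoro in place of methyl on an aromatic carbon. For the measured compounds named here, the only measured step that bears on it is methyl in place of bromo on the same aromatic carbon, which gave a 1.0-fold higher number from compound 1 to compound 2 (0.02 log units; within the scatter). Going by the values given here, that is one step between two compounds, so the basis is thin, and no fluoro compound has yet been measured. Even so, the one exchange seen at this place left the number unmoved, so no step beyond the scatter is expected in this assay, and no direction is favoured.

The expected step is a 1.0-fold lower number from compound 2 to compound 3 (0.02 log units; within the scatter). The estimate for compound 3 is 8000 nM, with an expected range from 4000 nM to 15000 nM.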

Compound 3, half-maximal inhibitory concentration: 6580 nM
Compound 3: middle estimate off by 1.2-fold (0.08 log units), on the high side; low and high end bracket the measured number.
By their numbers in this assay, from the lowest: compounds 3, 1 and 2 (each within the scatter of the next).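

In this assay the exchange of methyl for fluoro on this aromatic carbon, para to a large group, gives a 1.3-fold lower number from compound 2 to compound 3 (0.11 log units; within the scatter) and the exchange of bromo for fluoro gives a 1.2-fold lower number from compound 1 to compound 3 (0.09 log units; within the scatter) and so neither step separates the compounds. Among the compounds shown here, the earlier pair showed only that one exchange at this place left the number level, whereas compound 1, compound 2 and compound 3 now show that bromo, methyl and fluoro all read alike here, with no step beyond the scatter among them. Within these three compounds the 4-fluorophenyl, 4-methylphenyl and 4-bromophenyl forms of the (aryl)amino group are therefore interchangeable in this read-out, and the series gives no ranking among them.

Going by these compounds, whether a group of another kind at the same place, such as a carboxylic acid, an amine or a nitrile, would move the number beyond the scatter stays open, as does the effect of any change elsewhere on the shared core, which is the same in all three compounds. No measured evidence is at hand that bears on this result.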